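A few compounds are considered here, and "the series" means these few. Any claim that something is new, unique, unknown or untested is made for them only; others in the source may bear on it.

Measured in a functional assay on HepG2 cells (Homo sapiens) for antiproliferative activity, read by MTT assay, with a stated time of 72 h; a lower number here means a stronger inhibitor, a higher number a weaker inhibitor:
- Compound 1 `COc1ccc(N2C(=O)COc3ccc(-c4cnc(Cl)c(NS(=O)(=O)c5ccc(F)cc5)c4)cc32)cc1`: > 40000 nM, a limit of the assay
- Compound 2 `CC(C)N1C(=O)COc2ccc(-c3cnc(Cl)c(NS(=O)(=O)c4ccc(F)cc4)c3)cc21`: 21500 nM

Among the compounds with values here, compound 2, at 21500 nM, holds the only actual number so far. Compound 3 `Cc1ccc(N2C(=O)COc3ccc(-c4cnc(Cl)c(NS(=O)(=O)c5ccc(F)cc5)c4)cc32)cc1` carries 4-methylphenyl in place of isopropyl on an amide-type nitrogen in a ring. Within the data shown here, the one measured step bearing on this is the exchange of 4-methoxyphenyl for isopropyl at that nitrogen, an at least 1.8-fold lower number from compound 1 to compound 2 (0.26 log units; that floor lies within the scatter). The present change runs the other way, so a small move towards a higher number is expected, and it may stay within the scatter. The expected step is a 1.8-fold higher number from compound 2 to compound 3 (0.25 log units; within the scatter). For compound 3 the estimate is 38000 nM, with an expected range from 18000 nM to 80000 nM.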

Compound 3, half-maximal inhibitory concentration: 39600 nM
Estimate against measurement, compound 3: 1.0-fold (0.02 log units) below; the range from low to high includes it.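

In this assay, 4-methylphenyl in place of isopropyl on an amide-type nitrogen in a ring gives a 1.8-fold higher number from compound 2 to compound 3 (0.27 log units; within the scatter), so these two groups cannot be told apart at this position. Compound 3 thus provides an actual number for a group with an aromatic ring at this nitrogen. Methyl in place of methoxy on an aromatic carbon gives a number no higher from compound 1 to compound 3 (the limit leaves the size open). The size of this step cannot be read, because compound 1 stands at a limit of the assay: the limit of > 40000 nM in this assay, at which 1 of the 3 values shown sits.

As far as these compounds go, it remains open whether any group at this nitrogen moves the number beyond the scatter. A chain ending in an amine or a carboxylic acid, for instance, is not among the compounds shown.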